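Compound 1 to compound 3: adding one methyl

The source may report more compounds than this note shows. Statements on the series, on what has been measured and on what is new or still open speak of the compounds shown alone.

In an ADME assay for pharmacokinetics (a higher number here means that the compound lasts longer, a lower number that the compound disappears faster), compound 1 `NC(=O)c1ncn2c(=O)n(-c3ccccc3)nnc12` gives 0.383 h, the lower of the two numbers in hand. Compound 2 `CCCn1nnc2c(C(N)=O)ncn2c1=O` gives 2.58 h.

The next structure is compound 3 `Cc1ccc(-n2nnc3c(C(N)=O)ncn3c2=O)cc1`, reached from compound 1 by methyl in place of hydrogen on an aromatic carbon. In short, this is methyl in place of hydrogen on an aromatic carbon, para to a large group.

Within the data shown here, only one measured step is available: a 6.7-fold higher number from compound 1 to compound 2 (0.83 log units; beyond the scatter). That step has propyl in place of phenyl on an aromatic nitrogen, so the phenyl is lost altogether, whereas compound 3 retains it. Among the measured compounds shown here, the step bears on the new change only loosely, and no measured step shows a substitution on an aromatic carbon. Its size is therefore best read as an outer bound for a much smaller edit, and its direction carries little weight.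

A small upward shift in this assay, not beyond the scatter, is expected. The expected change is a 1.2-fold higher number from compound 1 to compound 3 (0.07 log units; within the scatter).

For compound 3, the estimated half-life is 0.45 h, with an expected range of 0.25 h to 0.85 h.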

Compound 3, half-life: 0.667 h
Estimate against measurement, compound 3: 1.5-fold (0.17 log units) below, within the range that was stated.
By their numbers in this assay, from the lowest: compounds 1 and 3 (each within the scatter of the next); then compound 2.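

Methyl in place of hydrogen on an aromatic carbon, para to a large group, is the first edit in the series that keeps the phenyl, and in this assay it gives a 1.7-fold higher number from compound 1 to compound 3 (0.24 log units; within the scatter). This position on the phenyl therefore takes one added methyl without a change in half-life that can be told from the scatter, so this single edit does not separate compound 3 from compound 1. Among these compounds, the only step beyond the scatter remains the replacement of the whole phenyl, a 6.7-fold higher number from compound 1 to compound 2 (0.83 log units; beyond the scatter), and nothing measured accounts for either step.

Still open, on these data alone, is whether a group other than methyl at this same place on the phenyl, such as a chlorine, an amine or a carboxylic acid, would move the half-life beyond the scatter while the phenyl stays in place. Also open, as far as these compounds go, is whether the step seen with propyl on the aromatic nitrogen carries over to a longer chain such as hexyl, or to a branched chain such as isopropyl.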